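Swapping vinyl for isobutyl on a shared core

The source may report more compounds than this note shows. Statements on the series, on what has been measured and on what is new or still open speak of the compounds shown alone.

Of the compounds shown here, three built on a shared core have been tested in a functional assay on HL-60 cells (Homo sapiens) for antiproliferative activity, read by MTT assay; on this read-out lower numbers stand for stronger inhibition and higher numbers for weaker inhibition. Among the measured compounds shown here, compound 1 (`O[C@@H]1[C@@H](OCc2ccccc2)[C@H](OCc2ccccc2)[C@@H](COCc2ccccc2)O[C@@H]1CC1CCCCC1`) gives 17200 nM, the only number in the set. Compound 2 (`CC(C)C[C@H]1O[C@H](COCc2ccccc2)[C@@H](OCc2ccccc2)[C@H](OCc2ccccc2)[C@@H]1O`) is reported as "not active" (no number reported). Compound 3 (`C=C[C@H]1O[C@H](COCc2ccccc2)[C@@H](OCc2ccccc2)[C@H](OCc2ccccc2)[C@H]1O`) is also reported as "not active" (no number reported), so it has no single number and stands alongside compound 2 rather than on a scale.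

Compound 4 (`CC(C)C[C@H]1O[C@H](COCc2ccccc2)[C@@H](OCc2ccccc2)[C@H](OCc2ccccc2)[C@H]1O`) has not yet been measured. The structural change is isobutyl in place of vinyl on a saturated ring carbon, next to the ring oxygen.

With no number for compound 3, the size of this step cannot be worked out from the data. In this assay, the expectation is for a small step at most, towards weak activity and no further. For the measured compounds named here, compound 1, at 17200 nM, is the only measured guide, and compound 4 is expected to land near it or weaker, or to return no number at all. If a number is reported, the estimate for compound 4 is 30000 nM, with an expected range from 12000 nM to 80000 nM.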

Compound 4, half-maximal inhibitory concentration: 13900 nM
Compound 4: middle estimate off by 2.2-fold (0.33 log units), on the high side; the measured number falls inside the stated range.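

The step from vinyl to isobutyl cannot be read as a size, as compound 3 has no number, but this position can carry a group that gives a measurable value in this assay. Swapping the end of the side chain changes little here, with isopropyl in place of cyclohexyl giving a 1.2-fold lower number from compound 1 to compound 4 (0.09 log units; within the scatter). Compound 2 also carries isobutyl yet is reported as not active, whereas compound 4 has a number, so the arrangement in space appears to decide whether any activity is seen: the fact that compounds 2 and 4 differ only in the configuration as drawn

On these data alone, it remains open whether an amine, a carboxylic acid or a chain longer than isobutyl at this position would give a clearly lower number. The compounds shown also leave open whether replacing a benzyloxy group with a free hydroxy group would keep this weak activity.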